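A urea swap carried onto a weaker core

The source may hold more compounds than are shown below. What is called first, only, known or untested is meant among the compounds shown, and "the series" means these compounds.

Compound 1 `CC(C)NC(=O)N1CCN(C(=S)SCc2cn(Cc3ccccc3F)nn2)CC1` and compound 2 `CCN(C)C(=O)N1CCN(C(=S)SCc2cn(Cc3ccccc3F)nn2)CC1` share one core and differ as ethyl(methyl)amino in place of isopropylamino on a carbonyl carbon. In a functional assay on SMMC-7721 cells (Homo sapiens) for cytotoxicity, read by MTT assay, with a stated time of 72 h (on this read-out higher numbers stand for weaker inhibition and lower numbers for stronger inhibition), compound 1 gives 7130 nM, and compound 2 gives 19700 nM; the step is a 2.8-fold higher number from compound 1 to compound 2 (0.44 log units; beyond the scatter). Compound 3 `COc1cc(Cn2cc(CSC(=S)N3CCN(C(=O)NC(C)C)CC3)nn2)cc(OC)c1OC` carries the isopropylamino group on another core; the difference between the two cores is not broken down here. In this assay compound 3 yields only a limit of the assay, > 128000 nM, which is the limit described by the limit of > 128000 nM in this assay, at which 1 of the 3 values shown sits. Compound 4 `CCN(C)C(=O)N1CCN(C(=S)SCc2cn(Cc3cc(OC)c(OC)c(OC)c3)nn2)CC1` differs from compound 3 as ethyl(methyl)amino in place of isopropylamino on a carbonyl carbon, the same change at the same place as before. The step is expected to be about a step that the limit leaves unreadable from compound 3 to compound 4, resting on the measured step of a 2.8-fold higher number from compound 1 to compound 2 (0.44 log units; beyond the scatter). Compound 4 is therefore estimated at 250000 nM, between 100000 nM and 700000 nM, most probably reported again only as a limit.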

Compound 4, half-maximal inhibitory concentration: > 128000 nM
Compound 4 ended at the assay's limit; the forecaster's own chance of this, stated with the estimate: 85%; the middle value does not contradict the limit.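

In this assay compound 3 and compound 4 both end at a limit of the assay, so no step between them can be read: the limit of > 128000 nM in this assay, at which 2 of the 4 values shown sit.

The compounds shown leave open whether ethyl(methyl)amino in place of isopropylamino changes the number on the core of compound 3 as it does on the core of compound 1.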